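This account rests on a few compounds, and the source may have more. Where it says the series, first, only, none or still open, it means among the compounds named here.

Among the measured compounds shown here, compound 2 `COc1ccc(-c2nc(C)nn2-c2cccc(C(=O)NCCCOc3ccccc3)c2)cc1` gives 3120 nM in a functional assay on PANC-1 cells (Homo sapiens), read by microscopy, crystal violet staining and transwell migration, with a stated time of 18 h, in the presence of a further agent that is not named here (a lower number here means a stronger inhibitor, a higher number a weaker inhibitor), the only true number so far. Compound 1 `COc1ccc(-c2nc(C)nn2-c2cccc(C(=O)NCCCc3ccc(Br)cc3)c2)cc1` gives > 20000 nM, which is a limit of the assay. For the measured compounds named here, the one measured step, an at least 6.4-fold lower number from compound 1 to compound 2 (0.80 log units; beyond the scatter), replaced 4-bromophenyl with phenoxy at the same place on the chain. Compound 3 `COc1ccc(-c2nc(C)nn2-c2cccc(C(=O)NCCCCCc3ccccc3)c2)cc1` differs from compound 2 by phenethyl in place of phenoxy on a saturated chain carbon, three bonds along the chain from an amide-type nitrogen, with phenethyl in place of phenoxy. Like compound 1, it lacks the phenoxy group, so part of the gain in an at least 6.4-fold lower number from compound 1 to compound 2 (0.80 log units; beyond the scatter) may be lost. The expected change is a modest weakening, a 2.2-fold higher number from compound 2 to compound 3 (0.35 log units; beyond the scatter). Compound 3 is estimated at 7000 nM, within an expected range of 2000 nM to 20000 nM.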

Compound 3, half-maximal inhibitory concentration: > 20000 nM
Compound 3: a limit, no number; the forecaster's own chance of this, stated with the estimate: 25%; middle value at least 2.8-fold (0.45 log units) from the limit.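

Phenethyl in place of phenoxy gives an at least 6.4-fold higher number from compound 2 to compound 3 (0.80 log units; beyond the scatter). Compound 3 keeps an unsubstituted phenyl ring, so losing the measurable value does not require a bromine on the ring; among these three compounds, only compound 2, with its phenoxy group, gives a true number. The step between the other two compounds cannot be read because both values are limits: the limit of > 20000 nM in this assay, at which 2 of the 3 values shown sit.

On these data alone, how far compound 3 lies beyond its limit stays unknown. Also open, as far as these compounds go, is whether an amine in place of the phenoxy oxygen, or a 4-bromophenoxy group, would keep a measurable value.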